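From a methyl-branched acid chain to an unsaturated one

The source may hold more compounds than are shown below. What is called first, only, known or untested is meant among the compounds shown, and "the series" means these compounds.

Measured so far in an ADME assay on the whole organism (strain CD-1) for pharmacokinetics, with Mus musculus as the target, at a dose of 3 mg/kg by the intravenous route; a higher number here means more compound in the circulation at the dose given, a lower number less compound in the circulation:
Compound 1 `CN(Cc1ccccc1OCCCCCC(=O)O)C(=O)c1ccc(-c2ccco2)cc1` gives 1100 ng.h/mL
Compound 2 `C[C@H](CCCOc1ccccc1CN(C)C(=O)c1ccc(-c2ccco2)cc1)CC(=O)O` gives 77700 ng.h/mL
Compound 3 `CN(Cc1ccccc1OCCC[C@@H]1C[C@H]1C(=O)O)C(=O)c1ccc(-c2ccco2)cc1` gives 40500 ng.h/mL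

Compound 2 stands far from the low end of these numbers (a 71-fold higher number from compound 1 to compound 2 (1.85 log units; beyond the scatter)), while its gap to the nearest value stays within the scatter (a 1.9-fold lower number from compound 2 to compound 3 (0.28 log units; within the scatter)). Compound 4 `C/C(=C\CCCOc1ccccc1CN(C)C(=O)c1ccc(-c2ccco2)cc1)C(=O)O` differs from it in one place (2-carboxyprop-1-en-1-yl in place of 1-(carboxymethyl)ethyl on a saturated chain carbon, three bonds along the chain from an oxygen on an aromatic ring), with 2-carboxyprop-1-en-1-yl in place of 1-(carboxymethyl)ethyl. The large step to compound 3 (a 37-fold higher number from compound 1 to compound 3 (1.57 log units; beyond the scatter)) shows that a second substituted acid chain also stayed high, so a fall to the level of compound 1 is not expected. A modest downward step is expected (a 2.2-fold lower number from compound 2 to compound 4 (0.35 log units; beyond the scatter)). Compound 4 is estimated at 35000 ng.h/mL (expected range 10000 ng.h/mL to 90000 ng.h/mL).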

Compound 4, area under the concentration-time curve: 1300 ng.h/mL
Estimate against measurement, compound 4: 27-fold (1.43 log units) above; the whole stated range lies above it.
By their numbers in this assay, from the lowest: compounds 1 and 4 (each within the scatter of the next); then compounds 3 and 2 (each within the scatter of the next).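

In this assay, the same count of heavy atoms with one more double bond outside aromatic rings and no defined stereocentre brings a sharp fall (a 60-fold lower number from compound 2 to compound 4 (1.78 log units; beyond the scatter)), and the cyclopropyl acid chain gives a similar gap (a 31-fold lower number from compound 3 to compound 4 (1.49 log units; beyond the scatter)). A substituted acid chain therefore does not by itself keep the number high, as 2-carboxyprop-1-en-1-yl stays within the scatter of the plain chain (a 1.2-fold higher number from compound 1 to compound 4 (0.07 log units; within the scatter)). Nothing at hand explains the fall. Still open, going by these compounds, is whether it follows the double bond or the place of the methyl, which a saturated 2-carboxypropyl chain would separate.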